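The source may report more compounds than this note shows. Statements on the series, on what has been measured and on what is new or still open speak of the compounds shown alone.

Measured in an ADME assay on CHO cells (Cricetulus griseus) for cytotoxicity, read by MTT assay; a higher number here means that more compound is tolerated, a lower number that less compound is tolerated:
- compound 1 `Fc1ccc(Nc2cc3[nH]c(Nc4ccc(N5CCNCC5)cn4)nc3cn2)cc1C(F)(F)F` gives 14000 nM
- compound 2 `Fc1ccc(Nc2cc3[nH]c(Nc4ccc(N5CCN(CC6CC6)CC5)cn4)nc3cn2)cc1C(F)(F)F` gives 41000 nM
- compound 3 `C[C@@H]1CN(c2ccc(Nc3nc4cnc(Nc5ccc(F)c(C(F)(F)F)c5)cc4[nH]3)nc2)C[C@H](C)O1` gives 8500 nM

Of these three, compound 2 has the highest number, so the most compound is tolerated. Compound 4 `Fc1ccc(Nc2cc3[nH]c(Nc4ccc(N5CCN(CC6CC6)CC5)cn4)nc3cn2)cc1F` is the next to be considered. It differs from compound 2 by fluoro in place of trifluoromethyl on an aromatic carbon, ortho to a fluoro group (fluoro in place of trifluoromethyl on an aromatic carbon).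

For the measured compounds named here, no measured step touches this site. Each one changes the amine ring instead: a 2.9-fold higher number from compound 1 to compound 2 (0.47 log units; beyond the scatter) for cyclopropylmethyl in place of hydrogen, a 1.6-fold lower number from compound 1 to compound 3 (0.22 log units; within the scatter) for 2,6-dimethylmorpholin-4-yl in place of piperazin-1-yl, and a 4.8-fold lower number from compound 2 to compound 3 (0.68 log units; beyond the scatter) for 2,6-dimethylmorpholin-4-yl in place of 4-(cyclopropylmethyl)piperazin-1-yl. These steps show only how far numbers have moved in this assay within this small set, and they give no direction for the new change. No step beyond the scatter is therefore expected, and the range stays wide. The expected step is a 1.1-fold lower number from compound 2 to compound 4 (0.03 log units; within the scatter), in no firm direction. Compound 4 is estimated at 38000 nM, with an expected range of 14000 nM to 100000 nM.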

Compound 4, half-maximal cytotoxic concentration: 1200 nM
The estimate for compound 4 lay 32-fold (1.50 log units) above the measured number; the measured number lies below the stated range.
By their numbers in this assay, from the lowest: compound 4; then compounds 3 and 1 (each within the scatter of the next); then compound 2.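

Until this point, every step in this assay changed the amine ring, so the other end of the molecule had not been tested. Turning the 4-fluoro-3-(trifluoromethyl)phenyl group into 3,4-difluorophenyl gives a 34-fold lower number from compound 2 to compound 4 (1.53 log units; beyond the scatter), a larger step than any seen on the amine ring, so this single aromatic carbon has a strong hold on how much compound the cells tolerate. No measurement available here explains why the cells tolerate less of compound 4.

One pair cannot show whether the same swap would lower the number as far with the piperazin-1-yl group of compound 1 or the 2,6-dimethylmorpholin-4-yl group of compound 3. Also open, on these data alone, is where a chloro, methyl or nitrile group on this carbon would land relative to trifluoromethyl and fluoro.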